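The source may report more compounds than this note shows. Statements on the series, on what has been measured and on what is new or still open speak of the compounds shown alone.

In an assay on a protein complex (Cavia porcellus) with sulfonylurea receptors; K-ATP channels (Homo sapiens) as the target (on this read-out higher numbers stand for weaker inhibition and lower numbers for stronger inhibition), the three measured compounds stand as follows.
Compound 1, `CCN(CC)C(=O)c1ccc(NC(=O)C(C)(O)C(F)(F)F)cc1`, gives > 30000 nM, which is a limit of the assay and not a number.
Compound 2, `CC(O)(C(=O)Nc1ccc(Sc2ccccc2)cc1)C(F)(F)F`, gives > 30000 nM, again only a limit.
Compound 3, `CC(O)(C(=O)Nc1ccc(-c2nn[nH]n2)cc1)C(F)(F)F`, gives > 30000 nM, also only a limit.

On the numbers shown, compound 3 therefore stands nowhere in particular: its value in this assay is a limit, and all three values sit at that same limit (the limit of > 30000 nM in this assay, at which 3 of the 3 values shown sit). None of the steps between the measured compounds can be read: a step that the two limits leave unreadable from compound 1 to compound 2, a step that the two limits leave unreadable from compound 1 to compound 3 and a step that the two limits leave unreadable from compound 2 to compound 3 are each hidden by the two limits on either side.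

Compound 4, `CC(O)(C(=O)Nc1ccc([C@@H](O)c2ccccc2)cc1)C(F)(F)F`, differs from compound 3 in one place: hydroxy(phenyl)methyl in place of 2H-tetrazol-5-yl on an aromatic carbon. Going by the values given here, no measured step bears on this change in a readable way, because every step so far is masked by the limit (the limit of > 30000 nM in this assay, at which 3 of the 3 values shown sit). The shared core has given no readable number with three different groups on that aromatic carbon, so the most likely outcome is expected to be another limit rather than a measurable inhibition. Compound 4 is estimated at 30000 nM, with a range from 5000 nM to 100000 nM. The step this estimate implies, a number no higher from compound 3 to compound 4 (the limit leaves the size open), is an expectation only and is not supported by any readable step in this assay.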

Compound 4, half-maximal inhibitory concentration: > 30000 nM
Compound 4: a limit, no number; the forecaster's own chance of this, stated with the estimate: 70%; the middle value lies on the limit itself.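

In this assay compound 4 gives > 30000 nM, a limit and not a number, so its steps from compound 1, compound 2 and compound 3 cannot be read: the limit of > 30000 nM in this assay, at which 4 of the 4 values shown sit. The compounds shown leave open whether any group on that aromatic carbon of the shared core gives a measurable inhibition, and how these four groups would rank.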